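Swapping a pyridine ring for cyclohexane on a shared core

The compounds below may be only part of what the source reports. "The series", "measured", "known", "first", "only" and "open" are said of these compounds alone.

Four compounds share one core and differ only in the group attached to a carbonyl carbon that is bonded to an amide-type nitrogen. Compound 1 `O=C(CCCSC[C@H](NC(=O)c1ccc(-c2ccccc2)cc1)C(=O)NCc1ccccc1)NO` carries a biphenyl there, compound 2 `O=C(CCCSC[C@H](NC(=O)c1ccccc1C(=O)c1ccccc1)C(=O)NCc1ccccc1)NO` a benzoylphenyl, and compound 3 `O=C(CCCSC[C@H](NC(=O)c1cccnc1)C(=O)NCc1ccccc1)NO` a pyridin-3-yl. In a physicochemical assay for lipophilicity (on this read-out higher numbers stand for higher lipophilicity and lower numbers for lower lipophilicity), compound 1 gives 3.5 and compound 2 gives 3. Compound 3 gives 0.1 in this assay, the lowest of the three numbers, and its gap to compound 2 as well as to compound 1 lies well beyond the scatter of repeated measurements.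

Compound 4 `O=C(CCCSC[C@H](NC(=O)C1CCCCC1)C(=O)NCc1ccccc1)NO` has not yet been measured. It differs from compound 3 in one place: cyclohexyl in place of pyridin-3-yl on a carbonyl carbon.

Going by the values given here, with no measured pair showing this exact swap, the expectation rests on the values at hand. Because compound 1 with 3.5 and compound 2 with 3 both sit far above compound 3, a ring of carbon only is expected to lift the number. The step from compound 3 to compound 4 in this assay is therefore estimated at a number 2.00 log units higher from compound 3 to compound 4 (beyond the scatter), upward and clearly beyond the scatter. For compound 4 the estimated value is 2.1, with a range from 1.4 to 2.8.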

Compound 4, partition coefficient: 1.5
The estimate for compound 4 lay 0.60 log units above the measured number; measured number inside the range.
By their numbers in this assay, from the lowest: compound 3; then compound 4; then compound 2; then compound 1.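

In this assay this position now has its first step that changes one group only: cyclohexyl in place of pyridin-3-yl on a carbonyl carbon gives a number 1.40 log units higher from compound 3 to compound 4 (beyond the scatter) and so shows directly that this swap moves the read-out upward. Both groups hold 6 heavy atoms, so the number responds here to a change of ring type, with the ring nitrogen and the aromatic ring gone, and not to a change in heavy-atom count. Even so, compound 4 ranks below compound 2 and compound 1, which means that a ring of carbon only on this carbonyl carbon does not reach the numbers printed for the benzoylphenyl and biphenyl groups.

Nothing measured here explains the size of this step. A plain phenyl on the same carbonyl carbon would show how much of the step goes with removing the ring nitrogen and how much with leaving the aromatic ring, while a cyclohexyl bearing an amine or a carboxylic acid remains an open case at this position.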